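Imidazole-core dihydroxyheptanoic acids: aryl swap on the core

This account rests on a few compounds, and the source may have more. Where it says the series, first, only, none or still open, it means among the compounds named here.

Measured so far:
compound 1, `O=C(O)C[C@H](O)C[C@H](O)CCn1c(C(F)(F)F)nc(-c2cccs2)c1-c1ccc(F)cc1`: 64 nM
compound 2, `O=C(O)C[C@H](O)C[C@H](O)CCn1c(C(F)(F)F)nc(-c2ccc(F)cc2)c1-c1cccc(Cl)c1`: 41 nM

Both compounds were tested in an assay on microsomes from liver for inhibition of 3-hydroxy-3-methylglutaryl-coenzyme A reductase (Rattus norvegicus); a lower number here means a stronger inhibitor, a higher number a weaker inhibitor. Compound 1 gives 64 nM in this assay, and compound 2 gives 41 nM. Compound 2 has the lower of the two numbers, but the gap to compound 1 lies within the scatter, so the two compounds cannot be ranked against each other.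

Compound 3, `O=C(O)C[C@H](O)C[C@H](O)CCn1c(C(F)(F)F)nc(-c2ccc(F)cc2)c1-c1ccc(C(F)(F)F)cc1`, has not been measured. It differs from compound 2 in one place: 4-(trifluoromethyl)phenyl in place of 3-chlorophenyl on an aromatic carbon. Within the data shown here, no measured pair covers this exchange, so nothing seen so far speaks to its effect. The two measured compounds carry different aryl groups on the core and still sit within the scatter of each other, which suggests this position tolerates variation, but that rests on a single pair.

For compound 3 the expected step is a 1.5-fold higher number from compound 2 to compound 3 (0.17 log units; within the scatter), that is, little change beyond the scatter, with a slight lean toward a weaker inhibitor. Compound 3 is therefore estimated at 60 nM, in the range 20 nM to 180 nM.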

Compound 3, half-maximal inhibitory concentration: > 1000 nM
Compound 3 gave a limit, no number; the forecaster's own chance of this, stated with the estimate: 2%; middle value at least 16-fold (1.22 log units) from the limit.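

In this assay, 4-(trifluoromethyl)phenyl in place of 3-chlorophenyl on this aromatic carbon gives an at least 24-fold higher number from compound 2 to compound 3 (1.38 log units; beyond the scatter), so this position does not accept every substituted phenyl group. The earlier compounds shown here could not show this, since compound 1 and compound 2 differ in more than one place and gave no step at this position. The reading for compound 3 is a limit of the assay and not a number, so the step gives only a minimum size, and how far compound 3 lies from compound 2 stays unknown: the limit of > 1000 nM in this assay, at which 1 of the 3 values shown sits.

The exchange changes both the substituent and its place on the phenyl ring, and the compounds shown do not tell which of the two accounts for the step; 4-chlorophenyl or 3-(trifluoromethyl)phenyl on the same carbon would separate them. Also open, as far as these compounds go, is whether the step is specific to trifluoromethyl or extends to other groups at the 4-position of this phenyl ring, such as a methyl, a methoxy or an amine.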